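Swapping the aryl ether for a phenylsulfonyl group

The compounds below may be only part of what the source reports. "The series", "measured", "known", "first", "only" and "open" are said of these compounds alone.

Of the compounds shown here, three sharing one core have been measured in an assay for inhibition of Thromboxane-A synthase (Homo sapiens), using microsomes; on this read-out lower numbers stand for stronger inhibition and higher numbers for weaker inhibition. Compound 1 `O=C(O)CC/C=C\CC1COC(c2ccc([N+](=O)[O-])cc2)OC1c1cccnc1` gives 39 nM. Compound 2 `CSc1ccc(OC(C)(C)C2OCC(C/C=C\CCC(=O)O)C(c3cccnc3)O2)c([N+](=O)[O-])c1` gives 22 nM. Compound 3 `COc1ccccc1OC(C)(C)C1OCC(C/C=C\CCC(=O)O)C(c2cccnc2)O1` gives 60 nM, the highest number of the three; its gap to compound 1 is within the scatter, while the step of a 2.7-fold higher number from compound 2 to compound 3 (0.44 log units; beyond the scatter) lies beyond it. For the measured compounds named here, the only single-site step so far is therefore this one, in which one aryl ether replaced another on the same oxygen.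

Compound 4 `CC(C)(C1OCC(C/C=C\CCC(=O)O)C(c2cccnc2)O1)S(=O)(=O)c1ccccc1` is the next member. Compared with compound 3 it carries phenylsulfonyl in place of 2-methoxyphenoxy on a saturated chain carbon bound to two saturated chain carbons and a saturated ring carbon. Here the oxygen linking the aromatic ring to the core is gone, and a sulfonyl sits in its place; no measured pair covers such a swap. Going by the values given here, the one step that bears on it, from compound 2 to compound 3, shows that changing the aromatic group at this position moved this assay by a modest amount, without overturning the series. On that basis the step of a 1.3-fold higher number from compound 3 to compound 4 (0.12 log units; within the scatter) is expected to be modest, if anything toward a weaker number. The estimate for compound 4 in this assay is 80 nM, with a range from 30 nM to 250 nM.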

Compound 4, half-maximal inhibitory concentration: 40 nM
Estimate against measurement, compound 4: 2.0-fold (0.30 log units) above; the measured number falls inside the stated range.
By their numbers in this assay, from the lowest: compounds 2, 1, 4 and 3 (each within the scatter of the next, the first and the last beyond it).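

For the compounds shown here, until now, the only groups at this place, in compound 2 and compound 3, were aromatic rings held through an ether oxygen, so nothing showed whether that oxygen could be exchanged. In this assay, replacing 2-methoxyphenoxy with phenylsulfonyl gives a 1.5-fold lower number from compound 3 to compound 4 (0.18 log units; within the scatter), which means that this pair cannot be told apart, even though both the link to the ring and the ring's methoxy group differ. A readable result therefore does not require the ether oxygen at this place, at least for this one pair, though the data shown offer no measurement that explains this.

Because two things differ at once, this pair cannot separate the effect of the sulfonyl from that of losing the methoxy group, and a 2-methoxyphenylsulfonyl group would be needed to do so. On these data alone, it also remains open what a carbonyl or an amine would give as the link at this place, and whether a chlorine on the ring of the phenylsulfonyl group would move the number beyond the scatter.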